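Aryl exchange on the fused ring nitrogen toward compound 4

A few compounds are considered here, and "the series" means these few. Any claim that something is new, unique, unknown or untested is made for them only; others in the source may bear on it.

Compound 1 `CSC(=O)N1CCC(Oc2ncnc3c2CCN3c2ccc(S(C)(=O)=O)cc2F)CC1` gives 135% in a functional assay on CHO-K1 cells with Glucose-dependent insulinotropic receptor (Homo sapiens) as the target, read by a luciferase reporter, with a stated time of 5 h (a lower number here means a smaller maximal response, a higher number a larger maximal response), and compound 2 `CN(C)S(=O)(=O)N1CCC(Oc2ncnc3c2CCN3c2ccc(S(C)(=O)=O)cc2F)CC1` gives 68%. Among the measured compounds shown here, the single measured step, a number 67 percentage points lower from compound 1 to compound 2 (beyond the scatter), concerns the group on the amine nitrogen in a ring, not the aryl group. Compound 3 `CC(C)OC(=O)N1CCC(Oc2ncnc3c2CCN3c2ccc(C#N)cn2)CC1` gives 105% and stands second of the three, below compound 1 and above compound 2, both gaps beyond the scatter. Compound 4 `Cc1cc(S(C)(=O)=O)ccc1N1CCc2c(OC3CCN(C(=O)OC(C)C)CC3)ncnc21` differs from compound 3 at another place: 2-methyl-4-(methylsulfonyl)phenyl in place of 5-cyanopyridin-2-yl on a nitrogen on an aromatic ring in a ring. For the measured compounds named here, no measured step touches this nitrogen, so the one step seen gives no direction for this exchange. The step of no change at the digits printed from compound 3 to compound 4 (within the scatter) is therefore expected to stay within the scatter. For compound 4 the estimate is 105%, ranging from 75% to 135%.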

Compound 4, largest response reached (reported as percent of maximum), in percent of the reference or control that the assay uses: 80%
Estimate against measurement, compound 4: 25 percentage points above; measured number inside the range.
By their numbers in this assay, from the lowest: compound 2; then compound 4; then compound 3; then compound 1.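

The group on the nitrogen on an aromatic ring is not neutral for the response: 2-methyl-4-(methylsulfonyl)phenyl in place of 5-cyanopyridin-2-yl gives a number 25 percentage points lower from compound 3 to compound 4 (beyond the scatter) in this assay. Earlier, only the group on the amine nitrogen in a ring had a measured step, so this is a second place where a single exchange moves the maximal response. No available evidence bears on this step. Still open, from the compounds shown here alone, is which part of the exchange carries the step: the nitrile, the ring nitrogen, the methyl or the methylsulfonyl. A 4-cyanophenyl or an unsubstituted phenyl group at this nitrogen would help separate these.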